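The source may report more compounds than this note shows. Statements on the series, on what has been measured and on what is new or still open speak of the compounds shown alone.

Measured compounds:
compound 1, `CCOC(=O)c1c(-c2c(Cl)c3ccccc3oc2=O)nn(-c2cccc(Cl)c2)c1C(=O)OCC`: 38000 nM
compound 2, `COC(=O)c1c(-c2cc3ccccc3oc2=O)nn(-c2ccccc2)c1C(=O)OC`: 28000 nM

In a functional assay on A549 cells (Homo sapiens) for cytotoxicity, read by MTT assay, with a stated time of 48 h (on this read-out lower numbers stand for stronger inhibition and higher numbers for weaker inhibition), compound 2 gives 28000 nM and compound 1 gives 38000 nM. These two numbers lie within the usual scatter of each other, so neither compound stands apart from the other. Compound 3, `COC(=O)c1c(-c2cc3ccccc3oc2=O)nn(-c2ccc(Br)cc2)c1C(=O)OC`, differs from compound 2 by bromo in place of hydrogen on an aromatic carbon. Among the compounds with values here, no pair of measured compounds shows a step of this kind, so the expectation rests on the structural change alone, and a small step with no clear direction is expected. Compound 3 is therefore estimated at 25000 nM, with a range from 10000 nM to 60000 nM. The step of a 1.1-fold lower number from compound 2 to compound 3 (0.05 log units; within the scatter) is expected to stay within the scatter.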

Compound 3, half-maximal inhibitory concentration: 165000 nM
Compound 3: middle estimate off by 6.6-fold (0.82 log units), on the low side; measured number above the stated range.
By their numbers in this assay, from the lowest: compounds 2 and 1 (each within the scatter of the next); then compound 3.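

In this assay, the change from phenyl to 4-bromophenyl gives a 5.9-fold higher number from compound 2 to compound 3 (0.77 log units; beyond the scatter) and so weaker inhibition. Within the data shown here, this position, on an aromatic carbon and para to a large group, is therefore not indifferent to substitution, as the earlier compounds could not show, and a single bromo is enough to move the number beyond the scatter. Nothing shown here gives a reason for this step.
From the compounds shown here alone, whether fluoro, chloro, a methoxy group or an amine at the same place would weaken inhibition as bromo does remains open.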